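This account rests on a few compounds, and the source may have more. Where it says the series, first, only, none or still open, it means among the compounds named here.

The three measured compounds share one core and differ only in the group carried on the saturated ring carbon of the oxazolidinone ring or on the chain attached to it. Compound 1 `O=C1O[C@@H](CO)CN1c1ccc(-n2cc(-c3ccccn3)cn2)c(F)c1` carries a hydroxy group there; in an ADME assay on HEK293-A cells (Homo sapiens) for cytotoxicity, read by MTT assay, with a stated time of 48 h (on this read-out higher numbers stand for weaker inhibition and lower numbers for stronger inhibition), compound 1 gives > 400 ug/mL, which is a limit of the assay and not a number. Compound 2 `O=C1CNC(=O)N1C[C@H]1CN(c2ccc(-n3cc(-c4ccccn4)cn3)c(F)c2)C(=O)O1` carries a 2,5-dioxoimidazolidin-1-yl group instead, and in this assay compound 2 gives > 400 ug/mL, again only a limit. Compound 3 `O=C1O[C@@H](Cn2ccnc2)CN1c1ccc(-n2cc(-c3ccccn3)cn2)c(F)c1` carries a 1H-imidazol-1-yl group, and in this assay compound 3 gives > 400 ug/mL, also a limit. The steps a step that the two limits leave unreadable from compound 1 to compound 2, a step that the two limits leave unreadable from compound 1 to compound 3 and a step that the two limits leave unreadable from compound 2 to compound 3 therefore cannot be sized, since (the limit of > 400 ug/mL in this assay, at which 3 of the 3 values shown sit). Compound 2 thus stands at the limit together with the two others; nothing ranks it among them.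

Compound 4 `CNC(=O)[C@H]1CN(c2ccc(-n3cc(-c4ccccn4)cn3)c(F)c2)C(=O)O1` is not yet measured. It differs from compound 2 as follows: methylcarbamoyl in place of (2,5-dioxoimidazolidin-1-yl)methyl on a saturated ring carbon. Among the measured compounds shown here, no measured step bears a readable size on this change; the only evidence is that every value so far sits at the limit. The expectation for compound 4 in this assay is therefore a value near that same limit, estimated at 400 ug/mL, ranging from 200 ug/mL to 800 ug/mL. The expected step of a number no higher from compound 2 to compound 4 (the limit leaves the size open) is accordingly estimated as none beyond the scatter.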

Compound 4, half-maximal inhibitory concentration: 342 ug/mL
For compound 4 the middle estimate is 1.2-fold (0.07 log units) above the measured one, within the range that was stated.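

In this assay, compound 4 is the first compound shown to give a number and not a limit, and the first to carry a group other than a substituted methyl on the saturated ring carbon next to the ring oxygen. The new steps are an at least 1.1-fold lower number from compound 2 to compound 4 (0.06 log units; that floor lies within the scatter), an at least 1.1-fold lower number from compound 3 to compound 4 (0.06 log units; that floor lies within the scatter) and an at least 1.1-fold lower number from compound 1 to compound 4 (0.06 log units; that floor lies within the scatter), so methylcarbamoyl on this carbon is compatible with a readable value, yet the floors alone do not show a real shift from any of the three other compounds. The true size of all three steps remains open because those compounds sit at the limit: the limit of > 400 ug/mL in this assay, at which 3 of the 4 values shown sit.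

The compounds shown leave open whether the readable value goes with methylcarbamoyl itself or with the loss of the chain carbon that carries the groups in compound 1, compound 2 and compound 3, since this one change replaces both at once. A methylcarbamoylmethyl group on the same ring carbon would separate those two readings, and a carboxylic acid or an amine at that place would show whether the value follows the amide.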